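The compounds below may be only part of what the source reports. "The series", "measured", "known", "first", "only" and "open" are said of these compounds alone.

Measured compounds:
- Compound 1 `Cc1c(C(=O)Nc2ccc(Oc3ncnc4[nH]cc(-c5ccccc5)c34)c(F)c2)c(=O)c2cc(Cl)ccc2n1C`: in an assay on isolated protein for inhibition of tyrosine-protein kinase receptor UFO (Homo sapiens), read by FRET and Z'-LYTE, with a stated time of 1.5 h (a higher number here means a weaker inhibitor, a lower number a stronger inhibitor), compound 1 gives 1890 nM
- Compound 2 `Cc1ccc2c(c1)c(=O)c(C(=O)Nc1ccc(Oc3ncnc4[nH]cc(-c5ccccc5)c34)c(F)c1)c(C)n2-c1ccccc1`: in this assay compound 2 gives 620 nM
- Compound 3 `CCc1c(C(=O)Nc2ccc(Oc3ncnc4[nH]cc(-c5ccccc5)c34)c(F)c2)c(=O)c2cc(C)ccc2n1C`: in this assay compound 3 gives 78 nM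

Compound 1 stands at the highest number of the three in this assay, so it is the weakest inhibitor of the set. Compound 2 is its nearest neighbour, and the gap between the two lies beyond the scatter; compound 3 is furthest away, at a number far lower than that of compound 1. No pair among these three differs in one place only, so the values can be compared but not read as single steps.

The step to compound 4 `Cc1c(C(=O)Nc2ccc(Oc3ncnc4[nH]cc(-c5ccccc5)c34)c(F)c2)c(=O)c2cc(C3CC3)ccc2n1C` is a single change from compound 1: cyclopropyl in place of chloro on an aromatic carbon. Compound 3, which carries a methyl on the same aromatic carbon together with an ethyl elsewhere, gives a much lower number than compound 1 in this assay, but two changes separate it from compound 1, so nothing is known about the effect of a carbon substituent at that place on its own. The expectation for compound 4 is therefore a modest move toward a lower number, a 2.4-fold lower number from compound 1 to compound 4 (0.37 log units; beyond the scatter), with wide uncertainty. Compound 4 is estimated at 800 nM in this assay, within a range from 200 nM to 3000 nM.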

Compound 4, half-maximal inhibitory concentration: 230 nM
The estimate for compound 4 lay 3.5-fold (0.54 log units) above the measured number, and the stated range covers the measured number.
By their numbers in this assay, from the lowest: compound 3; then compound 4; then compound 2; then compound 1.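

In this assay, cyclopropyl in place of chloro on an aromatic carbon of the six-membered ring gives an 8.2-fold lower number from compound 1 to compound 4 (0.91 log units; beyond the scatter), and nothing else in the structure changes. Within the data shown here, this is the first reading of this position on its own: the earlier compounds differed from one another in more than one place, so their values could not show whether the group on this aromatic carbon matters. The step now shows that the number in this assay responds to this one change, and that, in the setting of compound 1, the larger all-carbon cyclopropyl ring is tolerated here and goes with the lower number. Nothing measured in this set accounts for the size of the step.

Going by these compounds, whether the lower number is particular to cyclopropyl, or would also come with a methyl, an isopropyl, a methoxy or an amine on this aromatic carbon, stays open. Also open, on these data alone, is whether the same exchange would move the number to a similar extent with other groups elsewhere on the shared core, as in compound 2 or compound 3.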